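The source may report more compounds than this note shows. Statements on the series, on what has been measured and on what is new or still open speak of the compounds shown alone.

Measured so far:
compound 1 `Brc1cn2ccnc2c(-c2ccc3ncn(C4CCCCC4)c3c2)n1`: 47.6%
compound 2 `O=Cc1ccc(-c2cn3ccnc3c(-c3ccc4ncn(C5CCCCC5)c4c3)n2)cc1`: 47.8%
compound 3 `CC(=O)c1ccc(-c2cn3ccnc3c(-c3ccc4ncn(C5CCCCC5)c4c3)n2)cc1`: 12%

In a functional assay on MCF7 cells (Homo sapiens) for inhibition, read by sulforhodamine B assay, with a stated time of 48 h, tested at 10 uM (a lower number here means less inhibition, a higher number more inhibition at the concentration tested (going by the name of the read-out)), compound 3 gives 12%, the lowest of the three numbers; compound 1 gives 47.6% and compound 2 gives 47.8%, both well above it. The change from compound 3 to compound 4 `Clc1ccc(-c2cn3ccnc3c(-c3ccc4ncn(C5CCCCC5)c4c3)n2)cc1` is chloro in place of acetyl on an aromatic carbon, on an aromatic carbon of a six-membered aromatic ring of carbon only. Among the compounds with values here, no measured step swaps acetyl for chloro directly. Within the data shown here, the steps that bear on it are a number 35.8 percentage points lower from compound 2 to compound 3 (beyond the scatter) and a number 35.6 percentage points lower from compound 1 to compound 3 (beyond the scatter), both large drops that set compound 3 apart, and a number 0.2 percentage points higher from compound 1 to compound 2 (within the scatter), which shows a bromo on the core and a 4-formylphenyl giving about the same number. Removing the acetyl is therefore expected to undo much of that drop, though nothing measured shows what chloro itself does here. The expected step is a number 28 percentage points higher from compound 3 to compound 4 (beyond the scatter). Compound 4 is estimated at 40% in this assay, with a range from 15% to 60%.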

Compound 4, a percentage reported as inhibition, at one concentration (the size of the read-out at that concentration, not a potency): 21.8%
The estimate for compound 4 lay 18.2 percentage points above the measured number, and the stated range covers the measured number.
By their numbers in this assay, from the lowest: compounds 3 and 4 (each within the scatter of the next); then compounds 1 and 2 (each within the scatter of the next).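

In this assay the change from 4-acetylphenyl to 4-chlorophenyl gives a number 9.8 percentage points higher from compound 3 to compound 4 (within the scatter) and so the low reading of compound 3 is not unique to the acetyl group: a chloro at this place on the six-membered aromatic ring reads about the same. Compound 2 now stands apart from both, since the step to chloro gives a number 26 percentage points lower from compound 2 to compound 4 (beyond the scatter) and shows that the formyl group, not just any group at this place, goes with the higher reading. The step of a number 25.8 percentage points lower from compound 1 to compound 4 (beyond the scatter) adds that a phenyl ring carrying a group here does not always match the bromo on the core, and nothing available explains these differences.

Going by these compounds, what stays open is whether a phenyl ring with no added group would read like compound 2 or like compound 4. An amine or a carboxylic acid at this place could fall on either side.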